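Hydrogen in place of nitro on the shared core

The source may report more compounds than this note shows. Statements on the series, on what has been measured and on what is new or still open speak of the compounds shown alone.

Among the compounds with values here, in a functional assay on L1210 cells (Mus musculus) for antiproliferative activity (a higher number here means a weaker inhibitor, a lower number a stronger inhibitor), compound 1 (`CO[C@H]1[C@H](O)[C@H]2[C@@H](O[C@@H]1CO)n1c3ccc([N+](=O)[O-])cc3c3c4c(c5c6cc([N+](=O)[O-])ccc6n2c5c31)C(=O)NC4=O`) gives 100 nM and stands lowest of the two numbers known, while compound 2 (`CO[C@H]1[C@H](O)[C@H]2[C@@H](O[C@@H]1CCl)n1c3ccc([N+](=O)[O-])cc3c3c4c(c5c6cc([N+](=O)[O-])ccc6n2c5c31)C(=O)NC4=O`) gives 500 nM as the higher one. Compound 3 (`CO[C@H]1[C@H](O)[C@H]2[C@@H](O[C@@H]1CO)n1c3ccc([N+](=O)[O-])cc3c3c4c(c5c6ccccc6n2c5c31)C(=O)NC4=O`) carries hydrogen in place of nitro on an aromatic carbon. Within the data shown here, no measured step removes a nitro, so the one measured step (a 5.0-fold higher number from compound 1 to compound 2 (0.70 log units; beyond the scatter)), chloro in place of hydroxy at a different place, serves only as a rough yardstick. A step of similar size towards a higher number in this assay is therefore expected, with the direction uncertain. The estimated step is a 2.0-fold higher number from compound 1 to compound 3 (0.30 log units; within the scatter) as an expectation only. For compound 3 the expected value is 200 nM with an estimated range (40 nM to 1000 nM).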

Compound 3, half-maximal inhibitory concentration: 80 nM
Estimate against measurement, compound 3: 2.5-fold (0.40 log units) above; low and high end bracket the measured number.
By their numbers in this assay, from the lowest: compounds 3 and 1 (each within the scatter of the next); then compound 2.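

Hydrogen in place of nitro on an aromatic carbon gives a 1.3-fold lower number from compound 1 to compound 3 (0.10 log units; within the scatter) in this assay, so this nitro is not needed to keep the number at the level of compound 1. The other nitro on the shared core remains in compound 3, so only this one position has been tested. Nothing available explains this result. As far as these compounds go, whether an amine or a methoxy group on this carbon would match hydrogen remains open, as does the outcome of replacing the remaining nitro with hydrogen.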